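The source may report more compounds than this note shows. Statements on the series, on what has been measured and on what is new or still open speak of the compounds shown alone.

Working notes on the series.

Among the measured compounds shown here, three analogues of the shared core have a number so far. Compound 1 `COc1cc(Cc2cnc(/N=C3\C(=O)N(CN4CCN(c5c(F)cc6c(=O)c(C(=O)O)cn(C7CC7)c6c5F)CC4C)c4ccc(Cl)cc43)nc2N)cc(OC)c1OC` gives 67 ug/mL in an ADME assay on CCRF-CEM cells (Homo sapiens) for cytotoxicity, read by MTT assay, with a stated time of 5 days; on this read-out higher numbers stand for lower toxicity in this test and lower numbers for higher toxicity in this test. Compound 2 `COc1cc(Cc2cnc(/N=C3\C(=O)N(CN4CCN(c5ccc(F)cc5)CC4)c4ccc(Cl)cc43)nc2N)cc(OC)c1OC` gives 71 ug/mL in this assay. Compound 3 `COc1cc(Cc2cnc(/N=C3\C(=O)N(CN(Cc4ccccc4)Cc4ccccc4)c4ccc(Cl)cc43)nc2N)cc(OC)c1OC` gives 37.1 ug/mL in this assay. Compound 2 sits alongside compound 1 and compound 3 on these numbers: the gap from compound 2 to compound 1 and the gap from compound 2 to compound 3 both fall within the usual scatter of repeated measurements, so no order among the three can be read from them.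

Compound 4 `COc1cccc(N2CCN(CN3C(=O)/C(=N\c4ncc(Cc5cc(OC)c(OC)c(OC)c5)c(N)n4)c4cc(Cl)ccc43)CC2)c1` has not yet been measured in this assay. Against compound 2 the change is 3-methoxyphenyl in place of 4-fluorophenyl on an amine nitrogen in a ring.

For the measured compounds named here, no step between measured compounds that differ in one place is available, so the expectation for compound 4 rests on the spread of the three numbers alone, which shows no movement beyond the scatter among them. The step from compound 2 to compound 4 is therefore expected to be a 1.1-fold lower number from compound 2 to compound 4 (0.04 log units; within the scatter), that is, nothing beyond the scatter in either direction. For compound 4 in this assay an estimate of 65 ug/mL is expected, within a range of 30 ug/mL to 140 ug/mL.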

Compound 4, half-maximal cytotoxic concentration: 23.3 ug/mL
Compound 4: the middle estimate sits 2.8-fold (0.45 log units) above what was measured; measured number below the stated range.
By their numbers in this assay, from the lowest: compounds 4, 3, 1 and 2 (each within the scatter of the next, the first and the last beyond it).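

In this assay the exchange of 4-fluorophenyl for 3-methoxyphenyl on the amine nitrogen in the ring gives a 3.0-fold lower number from compound 2 to compound 4 (0.48 log units; beyond the scatter) and, on this read-out, the lower number stands for higher toxicity in this test. Among the compounds shown here, the group at this position therefore matters to the number: the change keeps one six-membered aromatic ring of carbon only, yet the step lies beyond the scatter, which no comparison among the earlier compounds could show. Nothing measured here bears on why the number moves.

The change swaps the substituent and its place on the phenyl ring together, so the compounds shown do not tell which of the two goes with the step. 4-Methoxyphenyl and 3-fluorophenyl would separate them, and unsubstituted phenyl would give a reference for both.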